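This account rests on a few compounds, and the source may have more. Where it says the series, first, only, none or still open, it means among the compounds named here.

Compound 1 `CC(C#CCn1ccnc1)N1CCCC1=O` gives in a functional assay on the whole organism for agonist activity, with Mus musculus as the target (a higher number here means that more compound is needed for the effect, a lower number that less compound is needed), only a limit of the assay, > 100 mg/kg.
Compound 2 `Cc1cncn1CC#CC(C)N1CCCC1=O` gives in this assay only a limit of the assay, > 100 mg/kg.
Compound 3 `CC(=O)NCC#CCn1ccnc1` gives in this assay only a limit of the assay, > 100 mg/kg.

All three values sit together at the limit of > 100 mg/kg in this assay, at which 3 of the 3 values shown sit. Compound 2 differs from compound 1 by methyl in place of hydrogen on an aromatic carbon, and the measured step that the two limits leave unreadable from compound 1 to compound 2 cannot be read, because both of its ends are limits. Compound 4 `CC(=O)NCC#CCn1cncc1C` differs from compound 3 by methyl in place of hydrogen on an aromatic carbon. This is the same kind of change: the only wording that differs is that the ring atom bears a group of 8 heavy atoms here, where in compound 1 it bears a large group. How the core of compound 3 differs from the core of compound 1 is not broken down here. Since compound 3 reaches only a limit, > 100 mg/kg, the step that the limit leaves unreadable from compound 3 to compound 4 is expected to be small and cannot be pinned down. Compound 4 is expected at 150 mg/kg, between 50 mg/kg and 500 mg/kg, most likely again reported only as a limit.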

Compound 4, dose for half-maximal effect: 66 mg/kg
Compound 4: middle estimate off by 2.3-fold (0.36 log units), on the high side; the range from low to high includes it.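

In this assay, as far as these compounds go, methyl in place of hydrogen on an aromatic carbon gives an at least 1.5-fold lower number from compound 3 to compound 4 (0.18 log units; that floor lies within the scatter), and that figure is only a floor, so the true size of the step stays unknown. The same change on the core of compound 1 cannot be read, as both of its ends are limits rather than numbers: the limit of > 100 mg/kg in this assay, at which 3 of the 4 values shown sit. The compounds therefore show a measured value after this change on one core only, and they do not show that the effect carries over to the core of compound 1.

From the compounds shown here alone, it remains open how compound 3 would compare if it had a number instead of a limit. Also open, going by these compounds, is whether an ethyl or an amine on that same aromatic carbon would give a measured value in this assay.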